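Taking away one methyl group: an expectation for compound 4

The source may report more compounds than this note shows. Statements on the series, on what has been measured and on what is new or still open speak of the compounds shown alone.

Measured compounds:
compound 1, `Cc1cccc(C)c1Nc1nc2nonc2nc1O`, > 100000 nM (a limit of the assay, not a number)
compound 2, `Cc1cc(C)c(Nc2nc3nonc3nc2O)c(C)c1`, 113000 nM
compound 3, `Cc1ccc(C(F)(F)F)cc1Nc1nc2nonc2nc1O`, 32800 nM

The three measured compounds share one core and differ in what sits on the six-membered aromatic ring of carbon only. In an assay on mitochondria from L6 cells (Rattus norvegicus) for activation, with a stated time of 90 min (on this read-out lower numbers stand for an effect already at smaller amounts and higher numbers for an effect only at larger amounts of compound), compound 2 gives 113000 nM. In this assay compound 3 gives 32800 nM, the lowest of the two readable numbers. For compound 1 this assay reports only a limit, > 100000 nM, and the step that the limit leaves unreadable from compound 2 to compound 1 cannot be read because of the limit of > 100000 nM in this assay, at which 1 of the 3 values shown sits. How compound 3 differs from compound 2 is not broken down here.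

Compound 4, `Oc1nc2nonc2nc1Nc1cccc(C(F)(F)F)c1`, has not yet been measured in this assay. It differs from compound 3 by hydrogen in place of methyl on an aromatic carbon. Compound 1 differs from compound 2 by hydrogen in place of methyl on an aromatic carbon, which is the same kind of change, but the surroundings differ: in compound 2 the methyl that leaves sits meta to two methyl groups and para to a large group, whereas in compound 3 it sits ortho to a large group and para to a trifluoromethyl group.

Going by the values given here, since the only measured instance of this kind of change is unreadable, the expectation for compound 4 rests mainly on the value of compound 3, 32800 nM. The step is expected to be about a 1.8-fold higher number from compound 3 to compound 4 (0.26 log units; within the scatter), with a real chance that only a limit is reported. Compound 4 is therefore estimated at 60000 nM, likely between 15000 nM and 200000 nM.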

Compound 4, half-maximal effective concentration: 13300 nM
Compound 4: the middle estimate sits 4.5-fold (0.65 log units) above what was measured, outside the stated range (below it).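

In this assay, hydrogen in place of methyl on an aromatic carbon, ortho to a large group and para to a trifluoromethyl group, gives a 2.5-fold lower number from compound 3 to compound 4 (0.39 log units; beyond the scatter), so in this one pair the loss of the methyl goes with a modest move towards smaller amounts of compound. This single readable instance shows what the change does in the surroundings of compound 3, but it does not establish a rule for the series, and it says nothing about why the number moves. Compound 1 has only a limit and not a number, so the step to it from compound 2 cannot be read, and the one other instance of this change can neither confirm nor contradict the result, because of: the limit of > 100000 nM in this assay, at which 1 of the 4 values shown sits.

The compounds shown carry only methyl and trifluoromethyl groups on the carbon ring, which leaves open how the read-out would respond to an amine, a carboxylic acid or a longer chain at the place of the trifluoromethyl group. On these data alone, it also remains open whether the same exchange of methyl for hydrogen would give a readable step of similar size and direction at other places on that ring.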